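A Furanyl Ether in Place of a Mesylate on Compound 3

A few compounds are considered here, and "the series" means these few. Any claim that something is new, unique, unknown or untested is made for them only; others in the source may bear on it.

Of the compounds shown here, three have been measured in a functional assay on KB cells (Homo sapiens) for cytotoxicity; a lower number here means a stronger inhibitor, a higher number a weaker inhibitor. Compound 1 `COc1ccc2c(c1)C(=O)C=CC2=O` gives 33900 nM, and compound 2 `CC(=O)Oc1ccc2c(c1)C(=O)C=CC2=O` gives 22100 nM; the step of a 1.5-fold lower number from compound 1 to compound 2 (0.19 log units; within the scatter) puts acetyl in place of methyl on an oxygen on an aromatic ring. Compound 3 `CS(=O)(=O)OC1=CC(=O)c2ccccc2C1=O` gives 7180 nM, the lowest number of the three and beyond the scatter from both others. Compound 4 `O=C1C=C(Oc2ccco2)C(=O)c2ccccc21` differs from compound 3 as follows: furan-2-yl in place of methylsulfonyl on an oxygen on an unsaturated carbon. For the measured compounds named here, the only measured step, from compound 1 to compound 2, also exchanges a group on an oxygen, yet on an aromatic ring rather than on an unsaturated carbon, and it stayed within the scatter; it gives only weak guidance here. For compound 4 the author therefore expects a step of a 1.1-fold lower number from compound 3 to compound 4 (0.04 log units; within the scatter) inside the scatter. Compound 4 is estimated at 6500 nM, with a range from 2200 nM to 20000 nM.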

Compound 4, half-maximal inhibitory concentration: 53400 nM
Estimate against measurement, compound 4: 8.2-fold (0.91 log units) below, outside the stated range (above it).
By their numbers in this assay, from the lowest: compound 3; then compounds 2, 1 and 4 (each within the scatter of the next, the first and the last beyond it).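

At this oxygen on an unsaturated carbon, the group carried matters in this assay: furan-2-yl in place of methylsulfonyl gives a 7.4-fold higher number from compound 3 to compound 4 (0.87 log units; beyond the scatter), a step beyond the scatter. The earlier exchange on an oxygen on an aromatic ring, a 1.5-fold lower number from compound 1 to compound 2 (0.19 log units; within the scatter), had shown no such separation. No measurement here offers an explanation for the step. From the compounds shown here alone, whether the loss of methylsulfonyl or the entry of furan-2-yl drives the change remains open, and so does what an amine or a longer alkyl chain on this oxygen would give.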